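Swapping an Aromatic Ring for a Short Chain

The source may hold more compounds than are shown below. What is called first, only, known or untested is meant among the compounds shown, and "the series" means these compounds.

- compound 1 `C=C1C(=O)O[C@H]2[C@H]1CC/C(COC(=O)Cn1cc(F)c(=O)n(Cc3ccc(Br)cc3)c1=O)=C\CC[C@@]1(C)O[C@@H]21` gives 2670 nM here
- compound 2 `C=C1C(=O)O[C@H]2[C@H]1CC/C(COC(=O)Cn1cc(F)c(=O)n(Cc3ccccc3F)c1=O)=C\CC[C@@]1(C)O[C@@H]21` gives 3770 nM here
- compound 3 `C=C1C(=O)O[C@H]2[C@H]1CC/C(COC(=O)Cn1cc(F)c(=O)n(Cc3ccc(F)c(F)c3)c1=O)=C\CC[C@@]1(C)O[C@@H]21` gives 2700 nM here

These values come from a functional assay on Bel-7402 cells (Homo sapiens) for antiproliferative activity, read by MTT assay, with a stated time of 72 h (on this read-out lower numbers stand for stronger inhibition and higher numbers for weaker inhibition), and they lie close together. Compound 3 at 2700 nM sits within the scatter of the other two compounds, so none of the three can be ranked above another. Exchanging one substituted aromatic ring for another has changed little so far, as the steps show (a 1.0-fold higher number from compound 1 to compound 3 (0.00 log units; within the scatter)) and (a 1.4-fold lower number from compound 2 to compound 3 (0.14 log units; within the scatter)) and (a 1.4-fold higher number from compound 1 to compound 2 (0.15 log units; within the scatter)).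

The move to compound 4 `C=C1C(=O)O[C@H]2[C@H]1CC/C(COC(=O)Cn1cc(F)c(=O)n(CCC)c1=O)=C\CC[C@@]1(C)O[C@@H]21` is different in kind (ethyl in place of 3,4-difluorophenyl on a saturated chain carbon bound to an aromatic nitrogen). Put another way, 3,4-difluorobenzyl gives way to propyl. The measured steps bear on this only indirectly, since each keeps an aromatic ring and none removes it. The data therefore hold no direct guide, and compound 3 at 2700 nM serves as the starting point. In this assay the expected step is small (a 1.5-fold higher number from compound 3 to compound 4 (0.17 log units; within the scatter)) and leans towards a higher number, with wide uncertainty. For compound 4 the estimated value is 4000 nM and the expected range runs from 1500 nM to 12000 nM as a rough guide.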

Compound 4, half-maximal inhibitory concentration: 8580 nM
Compound 4: middle estimate off by 2.1-fold (0.33 log units), on the low side; the measured number falls inside the stated range.
By their numbers in this assay, from the lowest: compounds 1, 3 and 2 (each within the scatter of the next); then compound 4.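

In this assay, exchanging one substituted aromatic ring for another gave no readable difference, but removing the ring at this place does: replacing 3,4-difluorobenzyl with propyl gives a weaker result (a 3.2-fold higher number from compound 3 to compound 4 (0.50 log units; beyond the scatter)), and the comparisons with the other two rings point the same way (a 2.3-fold higher number from compound 2 to compound 4 (0.36 log units; beyond the scatter)) and (a 3.2-fold higher number from compound 1 to compound 4 (0.51 log units; beyond the scatter)). Each step is modest but lies beyond the scatter, so among these four compounds the three with an aromatic ring on this chain carbon all give lower numbers than compound 4, with none going against that pattern. Nothing measured here speaks to what lies behind this step.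

The change takes away the aromatic ring and shortens the group in one move, so these compounds cannot show which of the two matters; a longer chain such as hexyl, or a saturated ring such as cyclohexylmethyl, would help to pull them apart. Also open, from the compounds shown here alone, is how a chain ending in an amine or a carboxylic acid would fare at this place.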